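A few compounds are considered here, and "the series" means these few. Any claim that something is new, unique, unknown or untested is made for them only; others in the source may bear on it.

Of the compounds shown here, three have been measured in a functional assay on MCF7 cells (Homo sapiens) for inhibition, read by MTT assay, with a stated time of 72 h; on this read-out lower numbers stand for stronger inhibition and higher numbers for weaker inhibition. In this assay, compound 1 `Cc1cc(Nc2cc(-c3cccs3)[nH]n2)n2nc(SCc3ccc(Br)cc3)nc2n1` gives 5370 nM and compound 3 `CCCCCc1c(C)nc2nc(SCc3ccc(Cl)cc3)nn2c1Nc1cc(-c2ccccc2)[nH]n1` gives 6390 nM, two values within the usual scatter of each other. Compound 2 `Cc1cc(Nc2cc(-c3ccccc3)[nH]n2)n2nc(SCC3CCCCC3)nc2n1` has no number, only a limit of > 50000 nM. Among the measured compounds shown here, it is the one compound that stands at the limit of > 50000 nM in this assay, at which 1 of the 3 values shown sits.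

For the measured compounds named here, no two measured compounds differ in only one place, so no measured step is available as a guide. Compound 4 `C=CCSc1nc2nc(C)cc(Nc3cc(-c4ccccc4)[nH]n3)n2n1` has not yet been measured. It departs from compound 2 in one place: vinyl in place of cyclohexyl on a saturated chain carbon bound to a sulfur. This puts vinyl in place of cyclohexyl on a saturated chain carbon bound to a sulfur. Cut one bond further out, the same difference reads cyclohexylmethyl to allyl.

The starting point is only a limit, so the size of the step in this assay cannot be fixed closely. A modest move towards stronger inhibition is expected, and compound 4 may well remain at the limit. The estimated change is an at least 1.6-fold lower number from compound 2 to compound 4 (0.22 log units; that floor lies within the scatter). Compound 4 is expected at 30000 nM, with an estimated range from 10000 nM to 50000 nM.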

Compound 4, half-maximal inhibitory concentration: > 50000 nM
Compound 4 ended at the assay's limit (the forecaster's own chance of this, stated with the estimate: 45%); middle value at least 1.6-fold (0.22 log units) away from the limit.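

In this assay compound 4 gives only a limit, as compound 2 does, so no step can be read from compound 2 to compound 4: the limit of > 50000 nM in this assay, at which 2 of the 4 values shown sit.

The compounds shown leave open whether vinyl in place of cyclohexyl on a saturated chain carbon bound to a sulfur changes inhibition at all, and by how much.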